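The compounds below may be only part of what the source reports. "The series", "measured", "known", "first", "only" and "open" are said of these compounds alone.

Measured so far in a functional assay on P388 cells (Mus musculus) for cytotoxicity; a higher number here means a weaker inhibitor, a lower number a stronger inhibitor

- compound 1 `Cc1cc(-c2c(F)cc3c(=O)c(Cc4c(O)cccc4O)cn(C4CC4)c3c2F)cc(C)n1` gives 250 nM
- compound 2 `Cc1cc(-c2c(F)cc3c(=O)c(Cc4ccc(Cl)cc4)cn(C4CC4)c3c2F)cc(C)n1` gives 20000 nM
- compound 3 `Cc1cc(-c2c(F)cc3c(=O)c(Cc4ccc[nH]4)cn(C4CC4)c3c2F)cc(C)n1` gives 930 nM

These compounds share a core and differ only in the group on a saturated chain carbon bound to an aromatic carbon. Compound 3 holds the middle place of the three numbers. It lies closer to compound 1, with a 3.7-fold higher number from compound 1 to compound 3 (0.57 log units; beyond the scatter), and well away from compound 2, with a 22-fold lower number from compound 2 to compound 3 (1.33 log units; beyond the scatter).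

The next compound is compound 4 `Cc1cc(-c2c(F)cc3c(=O)c(Cc4c(O)cc(O)cc4O)cn(C4CC4)c3c2F)cc(C)n1`, and the change is 2,4,6-trihydroxyphenyl in place of 1H-pyrrol-2-yl on a saturated chain carbon bound to an aromatic carbon. In words, 2,4,6-trihydroxyphenyl takes the place of 1H-pyrrol-2-yl.

Among the compounds with values here, no compound carrying this new group has been measured yet, so the nearest guide is compound 1, whose 2,6-dihydroxyphenyl group has the most similar name. Its modest step to compound 3 suggests that leaving the pyrrole for such a group should lower the number by a similar amount. The large 80-fold higher number from compound 1 to compound 2 (1.90 log units; beyond the scatter) gives a warning: a six-membered aromatic ring alone does not ensure a low number, so the range must stay wide.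

In this assay, a modest fall is therefore expected, an estimated 3.1-fold lower number from compound 3 to compound 4 (0.49 log units; beyond the scatter).

For compound 4 the estimated value is 300 nM, with an expected range from 80 nM to 1100 nM.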

Compound 4, half-maximal inhibitory concentration: 470 nM
Estimate against measurement, compound 4: 1.6-fold (0.19 log units) below; the measured number falls inside the stated range.
By their numbers in this assay, from the lowest: compounds 1, 4 and 3 (each within the scatter of the next, the first and the last beyond it); then compound 2.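

In this assay, hydroxy in place of hydrogen on an aromatic carbon leaves the result within the scatter (a 1.9-fold higher number from compound 1 to compound 4 (0.27 log units; within the scatter)), so this position accepts the extra hydroxy of 2,4,6-trihydroxyphenyl with no readable gain or loss. Going from 1H-pyrrol-2-yl to 2,4,6-trihydroxyphenyl is also within the scatter (a 2.0-fold lower number from compound 3 to compound 4 (0.30 log units; within the scatter)), so compound 4 cannot be told apart from compound 3 or from compound 1, even though those two differ from each other by more than the scatter. The new group does stand far from 4-chlorophenyl (a 43-fold lower number from compound 2 to compound 4 (1.63 log units; beyond the scatter)), which makes compound 2 the one clear outlier of the four, though no measurement on hand says why this is so.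

Going by these compounds, whether methoxy in place of each hydroxy, or a single hydroxy on the phenyl ring, would keep the number close to that of compound 1 remains open. So does the outcome for an amine or a carboxylic acid on the ring, or for a longer chain between the ring and the shared core.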